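The source may hold more compounds than are shown below. What is called first, only, known or untested is meant among the compounds shown, and "the series" means these compounds.

Among the compounds with values here, in a functional assay on MCF7 cells (Homo sapiens) for inhibition (a higher number here means a weaker inhibitor, a lower number a stronger inhibitor), compound 2 `CCCCCCCC[C@@]1(C)SC(O)=C(C(C)=O)C1=O` gives 12 ug/mL, the only number it has there, alongside one further entry without a single number. Compound 1 `CCCCCCCC[C@@]1(C)SC(O)=C(C(C)O)C1=O`, which shares its core, gives 17.6 ug/mL; 21.7 ug/mL (2 entries) in this assay, and the values of these two compounds lie within the scatter of each other. Compound 3 `CCCCCCCC[C@@]1(C)SC(O)=C(C(=O)OC)C1=O` has methoxy in place of methyl on a carbonyl carbon, so that acetyl becomes methoxycarbonyl. Within the data shown here, no measured pair shows this change, so the expectation rests on how close compound 1 at 17.6 ug/mL; 21.7 ug/mL (2 entries) and compound 2 at 12 ug/mL lie. In this assay the expected step of a 1.3-fold higher number from compound 2 to compound 3 (0.10 log units; within the scatter) is small, leaning slightly toward weaker inhibition and not expected to go beyond the scatter. For compound 3 the estimated value is 15 ug/mL, with an expected range from 6 ug/mL to 38 ug/mL.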

Compound 3, half-maximal inhibitory concentration: 18.7 ug/mL
Compound 3: middle estimate off by 1.2-fold (0.10 log units), on the low side; measured number inside the range.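

In this assay, the exchange of methoxy for methyl on this carbonyl carbon, which turns acetyl into methoxycarbonyl, gives a 1.6-fold higher number from compound 2 to compound 3 (0.19 log units; within the scatter). Within the data shown here, this is the first measured step at this position, and it shows that adding the oxygen of the methoxy leaves the number at a level that cannot be told apart from compound 2. Repeat entries for a single compound also differ from each other, as seen in this series: the several entries of compound 1 in this assay, 17.6 ug/mL; 21.7 ug/mL (2 entries)

The compounds shown leave open whether a carboxylic acid, a primary amide or a longer ester on this carbonyl carbon would move the number beyond the scatter. They also leave open whether a shorter chain on the shared core would change how these compounds read in this assay.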